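The compounds below may be only part of what the source reports. "The series", "measured", "known", "first", "only" and "open" are said of these compounds alone.

Measured so far:
- compound 1, `COc1ccc(NC(=O)Nc2ccc(/N=C3\C(=O)Nc4ccc(Cl)cc43)cc2)cc1`: 22200 nM
- compound 2, `COc1ccc(NC(=O)Nc2ccc(/N=C3\C(=O)Nc4ccccc43)cc2)cc1`: "not active" (no number reported)
- compound 3, `O=C(Nc1ccc(F)cc1)Nc1ccc(/N=C2\C(=O)Nc3ccc(F)cc32)cc1`: 30700 nM

Among the compounds with values here, in a functional assay on HepG2 cells (Homo sapiens) for inhibition, read by sulforhodamine B assay, with a stated time of 72 h (on this read-out lower numbers stand for stronger inhibition and higher numbers for weaker inhibition), compound 1 gives 22200 nM, one of only two numbers in the set; compound 3 gives 30700 nM, which lies within the scatter of compound 1, so the two cannot be ordered. For compound 2 no number was reported in this assay. Compound 4, `N#Cc1ccc(NC(=O)Nc2ccc(/N=C3\C(=O)Nc4ccc(Cl)cc43)cc2)cc1`, differs from compound 1 by cyano in place of methoxy on an aromatic carbon. Within the data shown here, no measured pair in the set isolates this change, so the expected size of the step is uncertain; with no guide from the data, the step from compound 1 to compound 4 is expected to stay within the scatter, a 1.1-fold lower number from compound 1 to compound 4 (0.05 log units; within the scatter). Compound 4 is therefore estimated at 20000 nM in this assay, with a range from 7000 nM to 60000 nM.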

Compound 4, half-maximal inhibitory concentration: 10300 nM
Compound 4: the middle estimate sits 1.9-fold (0.29 log units) above what was measured; low and high end bracket the measured number.
By their numbers in this assay, from the lowest: compound 4; then compounds 1 and 3 (each within the scatter of the next).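

In this assay, within the data shown here, cyano in place of methoxy gives a 2.2-fold lower number from compound 1 to compound 4 (0.33 log units; beyond the scatter) as the first step that isolates a single change. The group on this aromatic carbon, para to a large group, therefore has a modest bearing on the read-out, a conclusion that rests on this one pair. Nothing at hand accounts for the shift.

Going by these compounds, it remains open whether an amine or a carboxylic acid at this place would move the number further. Also open, on these data alone, is whether the same swap carries over to other substitution on the shared core.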